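Benzamide-to-urea swap at the ring amine nitrogen

The compounds below may be only part of what the source reports. "The series", "measured", "known", "first", "only" and "open" are said of these compounds alone.

Compound 3 `NC(=O)c1c(NC(=O)c2ccccc2F)sc2c1CCN(Cc1ccc(Cl)cc1Cl)C2` gives 13100 nM in a functional assay on HL-60 cells (Homo sapiens) for antiproliferative activity, with a stated time of 24 h (a higher number here means a weaker inhibitor, a lower number a stronger inhibitor), the lowest of the three numbers, but its gaps to compound 1 `NC(=O)c1c(NC(=O)c2ccc(C(F)(F)F)cc2)sc2c1CCN(Cc1ccc(Cl)cc1Cl)C2` at 14900 nM and compound 2 `Cc1ccc(C(=O)Nc2sc3c(c2C(N)=O)CCN(Cc2ccc(Cl)cc2Cl)C3)cc1` at 19900 nM are both within the scatter: a 1.1-fold lower number from compound 1 to compound 3 (0.06 log units; within the scatter), a 1.5-fold lower number from compound 2 to compound 3 (0.18 log units; within the scatter), and a 1.3-fold higher number from compound 1 to compound 2 (0.13 log units; within the scatter). Compound 4 `NC(=O)c1c(NC(=O)c2ccccc2F)sc2c1CCN(C(=O)Nc1ccccc1Cl)C2` differs from compound 3 at a different site: (2-chlorophenyl)carbamoyl in place of 2,4-dichlorobenzyl on an amine nitrogen in a ring. Among the compounds with values here, all three measured steps altered only the group on the carbonyl carbon and left the amine nitrogen untouched, so none bears directly on this change; they show only a flat series so far. Within the data shown here, with no bearing step, the expected step is a 1.0-fold lower number from compound 3 to compound 4 (0.00 log units; within the scatter), none beyond the scatter. Compound 4 is estimated at 13000 nM, with a range of 4000 nM to 40000 nM.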

Compound 4, half-maximal inhibitory concentration: 32700 nM
Estimate against measurement, compound 4: 2.5-fold (0.40 log units) below; measured number inside the range.
By their numbers in this assay, from the lowest: compounds 3, 1, 2 and 4 (each within the scatter of the next, the first and the last beyond it).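

Within the data shown here, the amine nitrogen in the ring is the first site here where a change moves the number in this assay beyond the scatter (a 2.5-fold higher number from compound 3 to compound 4 (0.40 log units; beyond the scatter)), whereas all earlier steps, on the carbonyl carbon, stayed within it. This position therefore responds to substitution, if modestly, and (2-chlorophenyl)carbamoyl gives a weaker inhibitor than 2,4-dichlorobenzyl. Nothing at hand explains the step.

From the compounds shown here alone, the change replaces the link and the chlorine pattern together, so their separate contributions remain open. Also open, going by these compounds, is how an unsubstituted benzyl or an acetyl group would read at this nitrogen.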